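The compounds below may be only part of what the source reports. "The series", "measured", "known", "first", "only" and "open" are said of these compounds alone.

Measured so far in a functional assay on PC-3 cells (Homo sapiens) for cytotoxicity, read by sulforhodamine B assay, with a stated time of 48 h; on this read-out higher numbers stand for weaker inhibition and lower numbers for stronger inhibition:
compound 1 `CC1=C(/C=C/C(=O)/C=C/c2ccccc2Br)C(C)(C)CCC1`, 11400 nM
compound 2 `CC1=C(/C=C/C(=O)/C=C/c2ccccc2F)C(C)(C)CCC1`, 3400 nM

Compound 2 gives the lowest number of the two; its nearest neighbour is compound 1, separated by a 3.4-fold lower number from compound 1 to compound 2 (0.53 log units; beyond the scatter). Compound 3 `CC1=C(/C=C/C(=O)/C=C/c2ccccc2C)C(C)(C)CCC1` differs from compound 2 by methyl in place of fluoro on an aromatic carbon. Going by the values given here, the only measured step at this spot is the bromo-to-fluoro exchange, a 3.4-fold lower number from compound 1 to compound 2 (0.53 log units; beyond the scatter), a modest change for a swap at the same place; a swap to methyl has no direct precedent here. The step from compound 2 to compound 3 is therefore expected to be small, a 1.3-fold higher number from compound 2 to compound 3 (0.12 log units; within the scatter), and compound 3 is estimated at 4500 nM, within 1500 nM to 13000 nM.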

Compound 3, half-maximal inhibitory concentration: 44100 nM
For compound 3 the middle estimate is 9.8-fold (0.99 log units) below the measured one, outside the stated range (above it).
By their numbers in this assay, from the lowest: compound 2; then compound 1; then compound 3.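

In this assay, a swap of one heavy atom on an aromatic carbon, ortho to a large group, can cost far more than the change between the two halogens showed. Methyl in place of fluoro gives a 13-fold higher number from compound 2 to compound 3 (1.11 log units; beyond the scatter), and methyl in place of bromo gives a 3.9-fold higher number from compound 1 to compound 3 (0.59 log units; beyond the scatter), leaving compound 3 the weakest of the three. No available evidence explains this loss.

As far as these compounds go, it remains open whether a methoxy group or an amine at this place would track compound 3 or the halogen-bearing compounds. Where chloro would fall is also unknown.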